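The compounds below may be only part of what the source reports. "The series", "measured", "known", "first", "only" and "open" are said of these compounds alone.

Measured in a functional assay on MCF7 cells (Homo sapiens) for cytotoxicity, read by MTT assay, with a stated time of 72 h; a higher number here means a weaker inhibitor, a lower number a stronger inhibitor:

compound 1 `O=C(N/N=C/c1ccc([N+](=O)[O-])cc1)Nc1cc2c(Nc3ccc(F)c(Cl)c3)ncnc2cc1O[C@H]1CCOC1`: "not active" (no number reported)
compound 2 `O=C(N/N=C/c1cccc(Cl)c1Cl)Nc1cc2c(Nc3ccc(F)c(Cl)c3)ncnc2cc1O[C@H]1CCOC1`: "not active" (no number reported)
compound 3 `O=C(N/N=C/c1cc(Br)c(O)c(Br)c1)Nc1cc2c(Nc3ccc(F)c(Cl)c3)ncnc2cc1O[C@H]1CCOC1`: 5910 nM

Compound 1 has no single number in this assay: it is reported as "not active" (no number reported). Compound 2 shares that outcome at "not active" (no number reported). Of the three measured compounds, only compound 3 gives a number, at 5910 nM. All three carry the same oxolan-3-yl group and differ from one another elsewhere in the structure.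

The unmeasured compound 4 `COc1cc2ncnc(Nc3ccc(F)c(Cl)c3)c2cc1NC(=O)N/N=C/c1ccc([N+](=O)[O-])cc1` keeps everything in compound 1 except that one group. The change is methyl in place of oxolan-3-yl on an oxygen on an aromatic ring. Put another way, (oxolan-3-yl)oxy becomes methoxy.

Within the data shown here, none of the measured compounds shows what this swap does, so any forecast is uncertain. Among the measured compounds shown here, the nearest guide is compound 1 at "not active" (no number reported), and the only number available comes from compound 3 at 5910 nM. A small step toward stronger inhibition in this assay is expected at most, and compound 4 may well again give no number. If a number is reported, the estimated value for compound 4 is 15000 nM, with an expected range from 4000 nM to 60000 nM.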

Compound 4, half-maximal inhibitory concentration: 36800 nM
Beside the measured number, compound 4's estimate is 2.5-fold (0.39 log units) below it; the measured number falls inside the stated range.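

In this assay compound 4 gives 36800 nM while compound 1 gives "not active" (no number reported), so no size can be put on the swap from (oxolan-3-yl)oxy to methoxy between these two compounds. Nothing shown here offers an explanation for this result. From the compounds shown here alone, what the same swap does to a compound with a reported number remains open.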